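The source may report more compounds than this note shows. Statements on the series, on what has been measured and on what is new or still open speak of the compounds shown alone.

For the measured compounds named here, in an ADME assay on cells (Mus musculus, strain BALB/c) for cytotoxicity, read by MTT assay, with a stated time of 24 h (on this read-out higher numbers stand for lower toxicity in this test and lower numbers for higher toxicity in this test), compound 2 `COc1cc(-c2nnc(SCc3ccccc3)o2)ccc1O` gives 211000 nM, the lower of the two numbers so far, while compound 1 `COc1cc(-c2nnc(SCc3ccc(C)cc3)o2)ccc1O` gives 549000 nM. Compound 3 `COc1cccc(CSc2nnc(-c3ccc(O)c(OC)c3)o2)c1` differs from compound 2 in one place: methoxy in place of hydrogen on an aromatic carbon. Going by the values given here, only one measured step bears on this, a 2.6-fold lower number from compound 1 to compound 2 (0.42 log units; beyond the scatter), and it is modest. It concerns methyl rather than methoxy, so it is a loose guide, but read in reverse it points towards a higher number. The expected step is a 1.4-fold higher number from compound 2 to compound 3 (0.15 log units; within the scatter). For compound 3 the estimated value is 300000 nM, with a range of 130000 nM to 650000 nM.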

Compound 3, half-maximal cytotoxic concentration: 389000 nM
Estimate against measurement, compound 3: 1.3-fold (0.11 log units) below; low and high end bracket the measured number.
By their numbers in this assay, from the lowest: compounds 2, 3 and 1 (each within the scatter of the next, the first and the last beyond it).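

In this assay the step of a 1.8-fold higher number from compound 2 to compound 3 (0.27 log units; within the scatter) replaces phenyl with 3-methoxyphenyl and stays within the scatter, whereas the earlier methyl step went beyond it. The step of a 1.4-fold lower number from compound 1 to compound 3 (0.15 log units; within the scatter) also stays within the scatter, so 3-methoxyphenyl and 4-methylphenyl cannot be told apart in this test. Nothing available explains these numbers. Still open, on these data alone, is whether an amine or a carboxylic acid on this aromatic ring, in place of methoxy, would shift the number beyond the scatter.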